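The source may hold more compounds than are shown below. What is called first, only, known or untested is meant among the compounds shown, and "the series" means these compounds.

Series notes: three measured analogues on one shared core. Compound 3 `O=C(COc1cccc2ccccc12)N/N=C/c1ccc(Br)cc1` gives 106 ug/mL in an ADME assay on MT4 cells (Homo sapiens) for cytotoxicity, read by MTT assay, with a stated time of 4 days (on this read-out lower numbers stand for higher toxicity in this test and higher numbers for lower toxicity in this test), the top of the three numbers shown, though only compound 2 lies beyond the scatter from it. Compound 1 `O=C(COc1cccc2ccccc12)N/N=C/c1ccc(Cl)cc1` gives 87.6 ug/mL in this assay, and a 1.2-fold higher number from compound 1 to compound 3 (0.08 log units; within the scatter). Compound 2 `O=C(COc1cccc2ccccc12)N/N=C/c1ccc(O)cc1` gives 26.5 ug/mL, with a 4.0-fold higher number from compound 2 to compound 3 (0.60 log units; beyond the scatter) and a 3.3-fold lower number from compound 1 to compound 2 (0.52 log units; beyond the scatter). Compound 4 `O=C(COc1cccc2ccccc12)N/N=C/c1ccc([N+](=O)[O-])cc1` is not yet measured; it differs from compound 3 by nitro in place of bromo on an aromatic carbon, para to a large group. Among the measured compounds shown here, no measured step swaps a halogen for a nitro group: the halogen swap stayed within the scatter, while the two hydroxy steps were modest. A step of a 1.3-fold lower number from compound 3 to compound 4 (0.12 log units; within the scatter) is therefore expected, small if any. Compound 4 is estimated at 80 ug/mL, within the range 35 ug/mL to 170 ug/mL.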

Compound 4, half-maximal cytotoxic concentration: 87.9 ug/mL
Beside the measured number, compound 4's estimate is 1.1-fold (0.04 log units) below it, and the stated range covers the measured number.
By their numbers in this assay, from the lowest: compound 2; then compounds 1, 4 and 3 (each within the scatter of the next).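

At this position on the aromatic ring, nitro does not separate from the halogens in this assay (a 1.2-fold lower number from compound 3 to compound 4 (0.08 log units; within the scatter); a 1.0-fold higher number from compound 1 to compound 4 (0.00 log units; within the scatter)), so the tolerated groups now extend beyond bromo and chloro to one with hydrogen-bond acceptors. Among the four compounds, only compound 2 stands apart, and nitro also shows that gap (a 3.3-fold higher number from compound 2 to compound 4 (0.52 log units; beyond the scatter)). Nothing at hand explains why hydroxy differs from the other three groups. On these data alone, whether an amine or a carboxylic acid here would track hydroxy or the other three stays open. A methoxy group would test whether the gap is specific to hydroxy.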